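Cytotoxicity at the limit: from acid to hydroxyethyl amide

The compounds below may be only part of what the source reports. "The series", "measured", "known", "first", "only" and "open" are said of these compounds alone.

Measured in an ADME assay on HOS cells (Homo sapiens) for cytotoxicity, read by luminescence and ATP content, with a stated time of 48 h (a lower number here means that less compound is tolerated, a higher number that more compound is tolerated), so far:
- compound 1 (`COC(=O)CNc1c(C(=O)NCc2ccc(F)cc2F)c(=O)n(O)c2nc(OC)ccc12`) gives 12000 nM as a number
- compound 2 (`Nc1c(C(=O)NCc2ccc(F)cc2F)c(=O)n(O)c2ncc(CCCOCCO)cc12`) gives > 250000 nM as a limit
- compound 3 (`Nc1c(C(=O)NCc2ccc(F)cc2F)c(=O)n(O)c2ncc(CCC(=O)O)cc12`) gives > 250000 nM as a limit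

Compound 3 gives > 250000 nM in this assay as a limit and not a number. It shares with compound 2 the limit of > 250000 nM in this assay, at which 2 of the 3 values shown sit, and so offers no exact starting point. Compound 4 (`Nc1c(C(=O)NCc2ccc(F)cc2F)c(=O)n(O)c2ncc(CCC(=O)NCCO)cc12`) differs from compound 3 by (2-hydroxyethyl)amino in place of hydroxy on a carbonyl carbon in one place, with (2-hydroxyethyl)amino in place of hydroxy on a carbonyl carbon. The nearest measured step is a step that the two limits leave unreadable from compound 2 to compound 3 and offers no size, so no step beyond the scatter is expected in this assay in either direction. Among the measured compounds shown here, compound 1 differs from the others in more than one place and supplies no step. The expected step is a number no higher from compound 3 to compound 4 (the limit leaves the size open) and no larger. Compound 4 is estimated at 250000 nM with an expected range from 100000 nM to 300000 nM and may well report only a limit.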

Compound 4, half-maximal cytotoxic concentration: > 250000 nM
Compound 4: only a limit was reported; the forecaster's own chance of this, stated with the estimate: 75%; the middle value lies on the limit itself.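

Compound 2, compound 3 and compound 4 each report only a limit in this assay, so no step among them can be read: the limit of > 250000 nM in this assay, at which 3 of the 4 values shown sit.

Going by these compounds, whether these three compounds differ at all in how much of each the cells tolerate remains open.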